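The source may hold more compounds than are shown below. What is called first, only, known or untested is meant among the compounds shown, and "the series" means these compounds.

In a functional assay on DU-145 cells (Homo sapiens) for inhibition, read by trypan blue exclusion, with a stated time of 96 h (on this read-out higher numbers stand for weaker inhibition of growth and lower numbers for stronger inhibition of growth), three compounds have been measured so far. Compound 1 `O=C(O)c1ccc(/C=C(/SCc2ccc(Cl)cc2)C(=O)c2ccc(C(=O)O)cc2)cc1` reports only a limit of the assay, > 100000 nM. Compound 3 `O=C(/C(=C\c1ccc(O)c([N+](=O)[O-])c1)SCc1ccc(Cl)cc1)c1ccc(Cl)cc1` gives 10000 nM, while compound 2 `O=C(/C(=C\c1ccccc1OCc1ccccc1)SCc1ccc(F)cc1)c1ccc(Cl)cc1` gives 1000 nM, the lower of the two actual numbers and beyond the scatter from compound 3. Compound 4 `O=C(/C(=C\c1ccccc1OCc1ccccc1)Sc1ccc(F)cc1)c1ccc(Cl)cc1` has 4-fluorophenyl in place of 4-fluorobenzyl on a sulfur. For the measured compounds named here, no measured pair isolates this change, so the expectation is tentative: a modest weakening of growth inhibition in this assay, slightly beyond the scatter. The expected step is a 2.5-fold higher number from compound 2 to compound 4 (0.40 log units; beyond the scatter). For compound 4 the estimated value is 2500 nM, with an expected range from 400 nM to 15000 nM.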

Compound 4, concentration for 50% growth inhibition: 1000 nM
The estimate for compound 4 lay 2.5-fold (0.40 log units) above the measured number; the range from low to high includes it.
By their numbers in this assay, from the lowest: compounds 2 and 4 (each within the scatter of the next); then compound 3. At a limit, above all of these: compound 1.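

In this assay, putting 4-fluorophenyl in place of 4-fluorobenzyl on the sulfur gives no change at the digits printed from compound 2 to compound 4 (within the scatter). For the compounds shown here, this is the first pair that differs in one place, and it shows that on this core the position takes either group with no measurable difference in growth inhibition. Nothing in the data shown gives a reason for this.

This single pair leaves open how the position responds to other groups on the sulfur, such as a longer chain ending in phenyl or a simple methyl. It also leaves open whether an amine on the ring would change the outcome.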